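This account rests on a few compounds, and the source may have more. Where it says the series, first, only, none or still open, it means among the compounds named here.

Notes on the series. Compound 1 `COc1ccc(/C=C/C[C@H]2C[C@@H]([C@@H](OC(C)=O)c3ccc(OC)c(OC)c3)CO[C@@H]2c2ccc(OC)c(OC)c2)cc1OC` carries an acetyl on the alcohol oxygen; in a functional assay on HeLa cells (Homo sapiens) for cytotoxicity, read by WST assay, with a stated time of 48 h (on this read-out lower numbers stand for stronger inhibition and higher numbers for weaker inhibition), compound 1 gives only a limit, > 100000 nM. Going by the values given here, compound 2 `COc1ccc(/C=C/C[C@H]2C[C@@H]([C@@H](O)c3ccc(OC)c(OC)c3)CO[C@@H]2c2ccc(OC)c(OC)c2)cc1OC` gives 23800 nM in this assay, the only number in the set. Among the compounds with values here, the measured step of an at least 4.2-fold lower number from compound 1 to compound 2 (0.62 log units; beyond the scatter) is the sole change at this oxygen, tied to the limit of > 100000 nM in this assay, at which 1 of the 2 values shown sits. Compound 3 `COc1ccc(/C=C/C[C@H]2C[C@@H]([C@@H](OC)c3ccc(OC)c(OC)c3)CO[C@@H]2c2ccc(OC)c(OC)c2)cc1OC` shows (methyl in place of hydrogen on an oxygen on a saturated carbon). Recapping the oxygen with a methyl, smaller than acetyl, is expected to give a step toward weaker inhibition, likely below the size of an at least 4.2-fold lower number from compound 1 to compound 2 (0.62 log units; beyond the scatter). Compound 3 is estimated at 50000 nM, range 15000 nM to 200000 nM, an expected step of a 2.1-fold higher number from compound 2 to compound 3 (0.32 log units; beyond the scatter).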

Compound 3, half-maximal inhibitory concentration: > 100000 nM
Compound 3 ended at the assay's limit (the forecaster's own chance of this, stated with the estimate: 35%); middle value at least 2.0-fold (0.30 log units) from the limit.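

In this assay the change from hydroxy to methoxy gives an at least 4.2-fold higher number from compound 2 to compound 3 (0.62 log units; beyond the scatter). Going by these compounds alone, the loss at this oxygen is therefore not peculiar to the acetyl, since a methyl there also takes the compound to the limit, and compound 2, with the free hydroxy, is the only one giving a number: the limit of > 100000 nM in this assay, at which 2 of the 3 values shown sit. The step between the two capped compounds cannot be read, as both values are limits.

Going by these compounds, whether an amine in place of the hydroxy would keep the inhibition of compound 2 remains open. How far either capped compound lies past the limit is also unknown.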